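This account rests on a few compounds, and the source may have more. Where it says the series, first, only, none or still open, it means among the compounds named here.

Measured compounds:
compound 1 `O=C(OCCCc1ccccc1)c1cc(-n2cc(-c3cccc(O)c3)nn2)ccc1O` — 11%
compound 2 `COC(=O)c1cc(-n2cc(-c3cc(O)ccc3O)nn2)ccc1O` — 15%
compound 3 `COC(=O)c1cc(-n2cc(-c3ccc(OC)cc3)nn2)ccc1O` — 6%

In a functional assay on HCT-116 cells (Homo sapiens) for inhibition, read by MTT assay, with a stated time of 2 days, tested at 10 uM (a higher number here means more inhibition at the concentration tested (going by the name of the read-out), a lower number less inhibition), compound 1 gives 11%. Its number sits amid the other two: compound 2 gives 15% and compound 3 gives 6%, and the gaps from compound 1 to each are within the usual scatter, so no ordering of the three can be read from these numbers.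

Compound 4 `COc1ccccc1-c1cn(-c2ccc(O)c(C(=O)OCCCc3ccccc3)c2)nn1` differs from compound 1 by 2-methoxyphenyl in place of 3-hydroxyphenyl on an aromatic carbon. Among the compounds with values here, the only measured step that bears on this kind of change is a number 9 percentage points lower from compound 2 to compound 3 (within the scatter), where a hydroxyl-bearing phenyl likewise gave way to a methoxyphenyl on the same aromatic carbon of the core, and the read-out did not move beyond the scatter. On that single precedent no change beyond the scatter is expected in this assay for compound 4, giving an estimated step of a number 2 percentage points lower from compound 1 to compound 4 (within the scatter). Compound 4 is therefore estimated at 9%, with a range of 0% to 22%.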

Compound 4, a percentage reported as inhibition, at one concentration (the size of the read-out at that concentration, not a potency): 7%
Estimate against measurement, compound 4: 2 percentage points above; the range from low to high includes it.
By their numbers in this assay, from the lowest: compounds 3, 4, 1 and 2 (each within the scatter of the next).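

Working from a number 4 percentage points lower from compound 1 to compound 4 (within the scatter) in this assay the exchange of 3-hydroxyphenyl for 2-methoxyphenyl, on the aromatic carbon of the five-membered aromatic ring with 3 nitrogen, stays within the scatter. Unlike the earlier step, this one is read with the phenylpropyl ester in place and also takes the phenyl substituent from 1 hydrogen-bond donor to 0 without a step beyond the scatter. No measured evidence explains the result.

Still open, as far as these compounds go, is whether an aminophenyl group at this position would give a step beyond the scatter. Also open, from the compounds shown here alone, is how a carboxylic acid in place of the ester would read.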